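Benzyl for 3-fluorophenyl on the urea series

The source may hold more compounds than are shown below. What is called first, only, known or untested is meant among the compounds shown, and "the series" means these compounds.

Measured in a functional assay on cells (Neutrophil, Homo sapiens) for inhibition, with a stated time of 10 min; on this read-out higher numbers stand for weaker inhibition and lower numbers for stronger inhibition:
- Compound 1 `CCOC(=O)c1cnn(CC(C)O)c1NC(=O)NCc1ccccc1`: 0.00054 nM
- Compound 2 `CCOC(=O)c1cnn(CC(O)CC)c1NC(=O)Nc1cccc(F)c1`: 0.36 nM

Of these two, compound 2 has the higher number at 0.36 nM, and the gap to compound 1 at 0.00054 nM lies beyond the scatter. Compound 3 `CCOC(=O)c1cnn(CC(O)CC)c1NC(=O)NCc1ccccc1` comes from compound 2 by benzyl in place of 3-fluorophenyl on an amide-type nitrogen. Within the data shown here, no measured one-place step is available to size this change in this assay, so the expectation is loose. A clear move towards stronger inhibition is expected, in the direction of compound 1 at 0.00054 nM. The expected step is a 36-fold lower number from compound 2 to compound 3 (1.56 log units; beyond the scatter). For compound 3 the estimated value is 0.01 nM, with an expected range of 0.0006 nM to 0.3 nM.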

Compound 3, half-maximal inhibitory concentration: 0.0074 nM
For compound 3 the middle estimate is 1.4-fold (0.13 log units) above the measured one; the measured number falls inside the stated range.
By their numbers in this assay, from the lowest: compound 1; then compound 3; then compound 2.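

In this assay, benzyl in place of 3-fluorophenyl on the amide-type nitrogen gives a 49-fold lower number from compound 2 to compound 3 (1.69 log units; beyond the scatter) and shows that this position responds strongly to the exchange. With benzyl held fixed, the side chain also counts: methyl in place of hydrogen on a saturated chain carbon, two bonds along the chain from an oxygen on a saturated carbon, gives a 14-fold higher number from compound 1 to compound 3 (1.14 log units; beyond the scatter) in the same assay. Nothing at hand accounts for either step.

Still open, on these data alone, is how much of the first step belongs to the fluorine and how much to the added carbon, a question that plain phenyl on that nitrogen would settle. Also open, as far as these compounds go, is how a longer chain such as 2-phenylethyl would read there.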